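Cyclopentyl on the sulfonamide nitrogen of compound 1

The source may report more compounds than this note shows. Statements on the series, on what has been measured and on what is new or still open speak of the compounds shown alone.

Measured in a functional assay on Huh-7 cells (Homo sapiens) for antiproliferative activity, read by CCK-8 assay, with a stated time of 72 h; on this read-out higher numbers stand for weaker inhibition of growth and lower numbers for stronger inhibition of growth:
compound 1 `CC[C@@H]1C(=O)N(C)c2cnc(Nc3ccc(S(=O)(=O)NC)cc3)nc2N1C1CCCC1` gives 99 nM
compound 2 `CCCNC(=O)c1ccc2c(ccn2-c2ncc3c(n2)N(C2CCCC2)[C@H](CC)C(=O)N3C)c1` gives 689 nM

Of these two compounds, compound 1 has the lower number and so shows the stronger inhibition of growth. The higher number of compound 2 lies beyond the usual scatter from that of compound 1. Within the data shown here, no pair of measured compounds differs in only one place, so the data offer no direct guide to a change at the sulfonamide nitrogen.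

Compound 3 `CC[C@@H]1C(=O)N(C)c2cnc(Nc3ccc(S(=O)(=O)NC4CCCC4)cc3)nc2N1C1CCCC1` keeps the core of compound 1 and carries cyclopentyl in place of methyl on a sulfonamide nitrogen. Without a measured precedent, the expectation is a modest rise in the number in this assay, meaning somewhat weaker inhibition of growth, although a result within the scatter would be no surprise. The only anchor for this expectation is compound 1 at 99 nM, so the range is kept wide. The expected change is a 2.0-fold higher number from compound 1 to compound 3 (0.31 log units; beyond the scatter). The estimate for compound 3 is 200 nM, within an expected range from 50 nM to 800 nM.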

Compound 3, concentration for 50% growth inhibition: 389 nM
Beside the measured number, compound 3's estimate is 1.9-fold (0.29 log units) below it, within the range that was stated.
By their numbers in this assay, from the lowest: compound 1; then compounds 3 and 2 (each within the scatter of the next).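

In this assay, the sulfonamide nitrogen now has its first direct reading: cyclopentyl in place of methyl gives a 3.9-fold higher number from compound 1 to compound 3 (0.59 log units; beyond the scatter), so this position responds to the exchange and methyl is the better of these two groups for inhibition of growth. The loss comes from a change that adds a five-membered non-aromatic ring of carbon only, with neither group bringing a hydrogen-bond donor, a hydrogen-bond acceptor or a net charge, although the step is described as modest and compound 3 keeps a measurable effect at 389 nM. Nothing available explains why the number rises with this exchange.

Among these compounds, with only two groups compared at this position, it remains open whether the number climbs steadily from methyl through ethyl and isopropyl to cyclopentyl, or whether the ring itself matters, which an open pentyl chain would help to separate. Also open, going by these compounds, is how the position responds to the unsubstituted sulfonamide with hydrogen on the nitrogen, or to a chain ending in an amine, a hydroxyl or a carboxylic acid.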